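This account rests on a few compounds, and the source may have more. Where it says the series, first, only, none or still open, it means among the compounds named here.

Measured so far in a functional assay on PC-3 cells (Homo sapiens) for antiproliferative activity, read by MTT assay, with a stated time of 24 h; a lower number here means a stronger inhibitor, a higher number a weaker inhibitor:
- Compound 1 `CCn1c(C(=O)N[C@@H](C)C(=O)OC)ccc1C(CC)(CC)c1ccc(OCS(=O)(=O)c2ccccc2)c(C)c1` gives only a limit of the assay, > 50000 nM.
- Compound 2 `CCn1c(C(=O)NC2(CO)CC2)ccc1C(CC)(CC)c1ccc(OCS(=O)(=O)c2ccccc2)c(C)c1` gives 3560 nM.
- Compound 3 `CCn1c(C(=O)N[C@H](CO)C(C)C)ccc1C(CC)(CC)c1ccc(OCS(=O)(=O)c2ccccc2)c(C)c1` gives 7300 nM.

Compound 3 stands at the highest of the two real numbers; its nearest neighbour is compound 2, and that step is a 2.1-fold higher number from compound 2 to compound 3 (0.31 log units; beyond the scatter). Compound 1 sits at the limit of > 50000 nM in this assay, at which 1 of the 3 values shown sits, so its steps to compound 2 and compound 3 are known only as bounds: an at least 14-fold lower number from compound 1 to compound 2 (1.14 log units; beyond the scatter) and an at least 6.8-fold lower number from compound 1 to compound 3 (0.83 log units; beyond the scatter).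

Compound 4 `CCn1c(C(=O)NC2(C(=O)O)CC2)ccc1C(CC)(CC)c1ccc(OCS(=O)(=O)c2ccccc2)c(C)c1` has not yet been tested. It differs from compound 3 in one place: 1-carboxycyclopropyl in place of 1-(hydroxymethyl)-2-methylpropyl on an amide-type nitrogen.

Two of the measured steps bear on this. Going from compound 3 back to compound 2 puts a three-membered ring on the same position, and that direction was a 2.1-fold higher number from compound 2 to compound 3 (0.31 log units; beyond the scatter) read backwards, a modest gain. Among the compounds with values here, replacing a hydroxymethyl group with a carboxy group has no measured counterpart here; the only other change at this position, the methoxycarbonyl group of compound 1, gave a bounded step, an at least 6.8-fold lower number from compound 1 to compound 3 (0.83 log units; beyond the scatter), towards weaker activity. On these data alone, the ring favours a lower number, the acid is untested, so the expected step of a 1.5-fold lower number from compound 3 to compound 4 (0.16 log units; within the scatter) is small and uncertain. Compound 4 is therefore estimated at 5000 nM, within 1500 nM to 30000 nM.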

Compound 4, half-maximal inhibitory concentration: 26300 nM
The estimate for compound 4 lay 5.3-fold (0.72 log units) below the measured number; the measured number falls inside the stated range.
By their numbers in this assay, from the lowest: compound 2; then compound 3; then compound 4. At a limit, above all of these: compound 1.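

In this assay, the cleanest reading of this position comes from the step with carboxy in place of hydroxymethyl on a saturated ring carbon (a 7.4-fold higher number from compound 2 to compound 4 (0.87 log units; beyond the scatter)). Within the data shown here, in this step the three-membered ring stays in place and only that group changes. Among these compounds, this is the first direct measure of the swap, and within this pair the hydroxymethyl compound has the lower number. The step that changes the open chain for 1-carboxycyclopropyl (a 3.6-fold higher number from compound 3 to compound 4 (0.56 log units; beyond the scatter)) also goes up, so the ring that accompanied the lower number in compound 2 does not offset the carboxy group in compound 4, and the comparison with the methoxycarbonyl compound survives only as a bound (an at least 1.9-fold lower number from compound 1 to compound 4 (0.27 log units; that floor lies within the scatter)) whose other end, for compound 1, is a limit and not a number: the limit of > 50000 nM in this assay, at which 1 of the 4 values shown sits.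

The compounds shown leave open how an aminomethyl group or a primary carboxamide on the same three-membered ring would compare with hydroxymethyl and carboxy. They also leave open whether a longer chain, such as hydroxyethyl, would keep the lower number of compound 2 or lose it.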